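The source may hold more compounds than are shown below. What is called first, only, known or untested is meant among the compounds shown, and "the series" means these compounds.

Measured compounds:
compound 1 `CCCS(=O)(=O)Nc1cccc2c1CCC2c1ncc[nH]1` — in a functional assay on CHO cells for agonist activity at Alpha-1D adrenergic receptor (Homo sapiens), read by FLIPR and calcium flux (on this read-out lower numbers stand for an effect already at smaller amounts and higher numbers for an effect only at larger amounts of compound), compound 1 gives > 10000 nM
compound 2 `CCS(=O)(=O)Nc1cccc(Cc2c[nH]cn2)c1` — compound 2 gives > 10000 nM
compound 3 `CS(=O)(=O)Nc1c(Cl)ccc2c1CCCC2c1ncc[nH]1` — compound 3 gives > 10000 nM

Compound 1 stands at the assay limit: its value is a limit, not a number. The value for compound 2 is likewise a limit. The value for compound 3 is a limit as well. No pair among these three differs in only one place, so no step between measured compounds is counted, and the three entries together show nothing beyond the common limit, (the limit of > 10000 nM in this assay, at which 3 of the 3 values shown sit).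

Compound 4 `c1ccc2c(c1)CCC2c1ncc[nH]1` is the next compound to be measured. It differs from compound 1 by hydrogen in place of (propylsulfonyl)amino on an aromatic carbon, in words hydrogen in place of (propylsulfonyl)amino on an aromatic carbon of the shared core. Going by the values given here, no measured step in this assay is available to set the size or direction of this change, and compound 1 itself offers no number because the limit of > 10000 nM in this assay, at which 3 of the 3 values shown sit, is all that is recorded for it. The expectation for the step from compound 1 to compound 4 is therefore a step that the limit leaves unreadable from compound 1 to compound 4, that is, no movement beyond the scatter that the data would reveal. Compound 4 is accordingly expected to give about 15000 nM, with a range from 3000 nM to 60000 nM, and most likely another limit.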

Compound 4, half-maximal effective concentration: > 10000 nM
Compound 4 gave a limit, no number (the forecaster's own chance of this, stated with the estimate: 80%); the middle value does not contradict the limit.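

In this assay no step can be read between compound 1 and compound 4, as both entries are limits and not numbers: the limit of > 10000 nM in this assay, at which 4 of the 4 values shown sit.

The compounds shown leave open whether any member of this series reaches a measurable value, and what (propylsulfonyl)amino on the shared core contributes to such a value.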